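The source may report more compounds than this note shows. Statements on the series, on what has been measured and on what is new or still open speak of the compounds shown alone.

Compound 1 `CC(C)(C)OC(=O)N1CCC(CCCNc2ccc3c(c2)OCC3=O)CC1`: 108%
Compound 2 `CC(C)(C)OC(=O)N1CCC(CCCNc2ccc3c(c2)S(=O)(=O)CC3)CC1`: "not determined" (no result reported)

Among the compounds with values here, in a functional assay on CHO-K1 cells for agonist activity at Glucose-dependent insulinotropic receptor (Mus musculus), read by HTRF and cAMP accumulation, with a stated time of 30 min (on this read-out higher numbers stand for larger maximal responses and lower numbers for smaller maximal responses), compound 1 gives 108%, the only number available here, since compound 2 stands as "not determined" (no result reported) in this assay. Compound 3 `COc1cnc(N2CCC(CCCNc3ccc4c(c3)OCC4=O)CC2)nc1` differs from compound 1 by one exchange: 5-methoxypyrimidin-2-yl in place of tert-butoxycarbonyl on an amine nitrogen in a ring. Within the data shown here, no measured pair shows what such an exchange does, so the expectation rests on compound 1 alone. The maximal response of compound 1 already sits at the level of the reference, and the expected step of a number 8 percentage points lower from compound 1 to compound 3 (within the scatter) is none beyond the usual scatter. Compound 3 is therefore estimated at 100% in this assay, within 70% to 120%.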

Compound 3, largest response reached (Emax), in percent of the reference or control that the assay uses: 106%
For compound 3 the middle estimate is 6 percentage points below the measured one, within the range that was stated.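

In this assay the exchange of tert-butoxycarbonyl for 5-methoxypyrimidin-2-yl on the ring's amine nitrogen gives a number 2 percentage points lower from compound 1 to compound 3 (within the scatter) and so leaves the maximal response in place. This position therefore carries either an open group or a six-membered aromatic ring with no change beyond the scatter. Nothing measured here explains why the response holds.

On these data alone, whether a much smaller group such as methyl, or a carboxylic acid, would keep this response stays open. The maximal response also says nothing about the concentration needed to reach it.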